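A few compounds are considered here, and "the series" means these few. Any claim that something is new, unique, unknown or untested is made for them only; others in the source may bear on it.

Measured in a functional assay (mast cells) for inhibition, with Rattus norvegicus as the target; on this read-out lower numbers stand for an effect already at smaller amounts and higher numbers for an effect only at larger amounts of compound:
compound 1 `CC1CC/C(=N\Nc2ccc(Br)cc2)c2ncc(C(=O)O)c(=O)n21`: 2000 nM
compound 2 `CC1CC/C(=N\Nc2ccc(O)cc2)c2ncc(C(=O)O)c(=O)n21`: 1300 nM
compound 3 `COc1ccc(N/N=C2\CCC(C)n3c2ncc(C(=O)O)c3=O)cc1`: 128000 nM

Compound 3 has the highest number of the three, so it needs the largest amount to show its effect. Compound 4 `CCOc1ccc(N/N=C2\CCC(C)n3c2ncc(C(=O)O)c3=O)cc1` differs from it in one place: methyl in place of hydrogen on a saturated chain carbon bound to an oxygen on an aromatic ring. In words, this is methyl in place of hydrogen on a saturated chain carbon bound to an oxygen on an aromatic ring, which turns methoxy to ethoxy.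

The nearest measured change also adds a methyl, turning hydroxy to methoxy, and it gave a 98-fold higher number from compound 2 to compound 3 (1.99 log units; beyond the scatter). Methoxy in place of bromo gave a 64-fold higher number from compound 1 to compound 3 (1.81 log units; beyond the scatter). Hydroxy in place of bromo gave only a 1.5-fold lower number from compound 1 to compound 2 (0.19 log units; within the scatter). Both large steps lead to the methoxy compound, so a small edit at this spot can matter greatly. Going by the values given here, no measured compound shows what lengthening methoxy to ethoxy does, however. The best guess is therefore that compound 4 stays close to compound 3, though it could fall well toward the other two. In this assay the expected outcome is a 1.3-fold lower number from compound 3 to compound 4 (0.11 log units; within the scatter). Compound 4 is estimated at 100000 nM, with an expected range from 8000 nM to 400000 nM.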

Compound 4, half-maximal effective concentration: 17600 nM
Compound 4: the middle estimate sits 5.7-fold (0.75 log units) above what was measured; the measured number falls inside the stated range.
By their numbers in this assay, from the lowest: compounds 2 and 1 (each within the scatter of the next); then compound 4; then compound 3.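

In this assay, going from methoxy to ethoxy gave a 7.3-fold lower number from compound 3 to compound 4 (0.86 log units; beyond the scatter) and so showed that the very high number of the methoxy compound does not simply grow as the group on this oxygen gets longer; one more methyl on the saturated chain carbon bound to the oxygen takes back part of the loss. The recovery is only partial, since ethyl in place of hydrogen on the oxygen still gives a 14-fold higher number from compound 2 to compound 4 (1.13 log units; beyond the scatter) and ethoxy in place of bromo gives an 8.8-fold higher number from compound 1 to compound 4 (0.94 log units; beyond the scatter) and leaves the ethoxy compound apart from both the hydroxy and the bromo compounds. Along the series hydroxy, methoxy, ethoxy the number therefore rises and then falls, so this position does not follow a steady trend with chain length, and nothing available here explains that turn.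

As far as these compounds go, what stays open is whether the number would keep falling with a longer chain on the oxygen, such as propoxy or butoxy, or would rise again. From the compounds shown here alone, it is also open how an amine or a chloro group at this spot on the aromatic ring would compare with the hydroxy, bromo and ethoxy groups.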